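The source may hold more compounds than are shown below. What is called first, only, known or untested is meant among the compounds shown, and "the series" means these compounds.

Measured compounds in an assay on CHO cells for displacement of a labelled ligand from 5-hydroxytryptamine receptor 1D (Homo sapiens); on this read-out higher numbers stand for weaker inhibition and lower numbers for stronger inhibition:

compound 1, `C[C@@H](NCC1CCN(CCCc2c[nH]c3ccc(-n4cnnc4)cc23)CC1)c1ccccc1`, 1.4 nM
compound 2, `CC(C)=CCCN(C)C1CCN(CCCc2c[nH]c3ccc(-n4cnnc4)cc23)CC1`, 2.6 nM
compound 3, `c1ccc(NCC2CCN(CCCc3c[nH]c4ccc(-n5cnnc5)cc34)CC2)nc1`, 1.7 nM

Compound 1 gives the smallest number of the three, but it is not set apart from the others: a 1.2-fold higher number from compound 1 to compound 3 (0.08 log units; within the scatter) and a 1.9-fold higher number from compound 1 to compound 2 (0.27 log units; within the scatter) both fall inside the scatter, so the three compounds read as one level on this assay.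

Compound 4, `c1ccc2c(c1)CCC2NCC1CCN(CCCc2c[nH]c3ccc(-n4cnnc4)cc23)CC1`, has not yet been measured in this assay. It differs from compound 1 in one place: 2,3-dihydro-1H-inden-1-yl in place of 1-phenylethyl on an amine nitrogen

Going by the values given here, the step that bears most directly on this change is the one from compound 1 to compound 3, where another group replaces 1-phenylethyl on the same amine nitrogen: a 1.2-fold higher number from compound 1 to compound 3 (0.08 log units; within the scatter). The larger rearrangement at the saturated ring carbon, a 1.9-fold higher number from compound 1 to compound 2 (0.27 log units; within the scatter), also stays within the scatter. The shared core is untouched in all three. No step beyond the scatter is therefore expected for compound 4; the move from compound 1 is estimated as a 1.3-fold higher number from compound 1 to compound 4 (0.11 log units; within the scatter). For compound 4 the expected value in this assay is 1.8 nM, with a range from 0.7 nM to 5 nM.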

Compound 4, half-maximal inhibitory concentration: 1.1 nM
Compound 4: the middle estimate sits 1.6-fold (0.21 log units) above what was measured; measured number inside the range.
By their numbers in this assay, from the lowest: compounds 4, 1, 3 and 2 (each within the scatter of the next, the first and the last beyond it).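

In this assay, 2,3-dihydro-1H-inden-1-yl on the amine nitrogen stays level with both groups previously held there, 1-phenylethyl (a 1.3-fold lower number from compound 1 to compound 4 (0.10 log units; within the scatter)) and pyridin-2-yl (a 1.5-fold lower number from compound 3 to compound 4 (0.19 log units; within the scatter)), so this position now carries a group with a five-membered non-aromatic ring without a step beyond the scatter. The set also gains its first step beyond the scatter, a modest one at the saturated ring carbon (a 2.4-fold lower number from compound 2 to compound 4 (0.37 log units; beyond the scatter)), although compound 1 and compound 3 remain within the scatter of both ends. No measured evidence is available to explain these steps.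

The compounds shown leave open whether this level holds with a methyl group or a carboxylic acid-bearing chain on the same amine nitrogen. On these data alone, compound 4 is drawn without a defined stereocentre, so the values of the separate stereoisomers also remain open.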